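The source may report more compounds than this note shows. Statements on the series, on what has been measured and on what is new or still open speak of the compounds shown alone.

Compound 3 `CC(C)=CCC/C(C)=C/CC1Cc2c(OCC=C(C)C)cc(=O)n(CCCO)c2CC1(C)C` gives 30.3% in a functional assay on PANC-1 cells (Homo sapiens) for inhibition, read by MTT assay, with a stated time of 24 h, tested at 10 uM (a lower number here means less inhibition, a higher number more inhibition at the concentration tested (going by the name of the read-out)), and stands highest of the three compounds measured there. Compound 1 `CC(C)=CCOc1cc(=O)n(CCCO)c2c1CC(CC=C(C)C)C(C)(C)C2` gives 20.7% in this assay and sits nearest to it, with the step of a number 9.6 percentage points higher from compound 1 to compound 3 (within the scatter) lying within the scatter. Compound 2 `COc1ccc(NC(=O)Oc2cc(=O)n(CCCO)c3c2CC(CC=C(C)C)C(C)(C)C3)cc1` gives 3.7% in this assay and lies furthest away, beyond the scatter.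

Compound 4 `CC(C)=CCC/C(C)=C/CC1Cc2c(OC(=O)Nc3ccc(F)cc3F)cc(=O)n(CCCO)c2CC1(C)C` has not yet been measured. It differs from compound 3 in one place: (2,4-difluorophenyl)carbamoyl in place of 3-methylbut-2-en-1-yl on an oxygen on an aromatic ring

Within the data shown here, the step that bears most on this change is the one from compound 1 to compound 2, where the same kind of replacement on the same oxygen gave a number 17 percentage points lower from compound 1 to compound 2 (beyond the scatter). The other step, a number 9.6 percentage points higher from compound 1 to compound 3 (within the scatter), concerns the part of the structure that compound 3 and compound 4 share and says little here. A modest fall beyond the scatter is therefore expected for compound 4 in this assay, of about a number 18.3 percentage points lower from compound 3 to compound 4 (beyond the scatter). Compound 4 is estimated to give 12%, with a likely range from 2% to 28%.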

Compound 4, a percentage reported as inhibition, at one concentration (the size of the read-out at that concentration, not a potency): 33.7%
For compound 4 the middle estimate is 21.7 percentage points below the measured one, outside the stated range (above it).
By their numbers in this assay, from the lowest: compound 2; then compounds 1, 3 and 4 (each within the scatter of the next, the first and the last beyond it).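

In this assay the step of a number 3.4 percentage points higher from compound 3 to compound 4 (within the scatter) shows that an arylcarbamoyl group on this oxygen does not always go with a loss of inhibition, since (2,4-difluorophenyl)carbamoyl replaces 3-methylbut-2-en-1-yl here without leaving the scatter. The earlier swap on the same oxygen, a number 17 percentage points lower from compound 1 to compound 2 (beyond the scatter), had suggested otherwise, but it differs from the new one both in the aryl group on the carbamoyl and in the chain on the core. Nothing available accounts for the difference between these two swaps.

The compounds shown leave open whether the aryl group or the chain on the core decides the outcome, as neither carbamoyl appears on both cores. They also leave open how this oxygen would respond to a carbamoyl bearing an unsubstituted phenyl, or to a chain ending in an amine or a carboxylic acid.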